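A methoxy group added to compound 2

The compounds below may be only part of what the source reports. "The series", "measured", "known", "first", "only" and "open" are said of these compounds alone.

Compound 1 `O=C(NO)c1ccc(/C=C/c2ccc(O)cc2)o1`: 21800 nM
Compound 2 `O=C(/C=C/c1ccc(/C=C/C(=O)c2ccc3ccccc3c2)o1)NO`: 15100 nM
Compound 3 `O=C(NO)c1ccc(/C=C/c2ccccc2O)o1`: 91300 nM

In a functional assay on PC-3 cells (Homo sapiens) for antiproliferative activity, read by MTT assay, with a stated time of 48 h (a higher number here means a weaker inhibitor, a lower number a stronger inhibitor), compound 2 gives 15100 nM. Among the compounds with values here, that number lies within the scatter of the one for compound 1, so the two cannot be told apart. Compound 3, at 91300 nM, stands beyond the scatter from compound 2, with a clearly higher number and so weaker inhibition.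

Compound 4 `COc1ccc2cc(C(=O)/C=C/c3ccc(/C=C/C(=O)NO)o3)ccc2c1` is compound 2 with one change, methoxy in place of hydrogen on an aromatic carbon. Within the data shown here, no two measured compounds differ in a single place, so the data offer no direct precedent for this change. With compound 2 at 15100 nM as the only close reference, no step beyond the scatter is expected in this assay, and no firm direction can be assigned. The expected step is a 1.2-fold lower number from compound 2 to compound 4 (0.07 log units; within the scatter), which would remain within the scatter. The estimated value for compound 4 is 13000 nM, with an expected range of 5000 nM to 35000 nM.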

Compound 4, half-maximal inhibitory concentration: 36300 nM
Beside the measured number, compound 4's estimate is 2.8-fold (0.45 log units) below it, outside the stated range (above it).
By their numbers in this assay, from the lowest: compounds 2, 1 and 4 (each within the scatter of the next, the first and the last beyond it); then compound 3.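

In this assay, within the data shown here, methoxy in place of hydrogen on this aromatic carbon of the fused system of two rings gives a 2.4-fold higher number from compound 2 to compound 4 (0.38 log units; beyond the scatter), and this is the first single-place comparison. The step is modest but beyond the scatter, so this position is not indifferent to the change, and the added methoxy goes with weaker inhibition rather than with a number that stays level. Nothing shown here accounts for this rise.

As far as these compounds go, the result rests on one pair of compounds, so it remains open whether an amine, a fluorine atom or an ethoxy group on the same carbon would move the number in the same direction. From the compounds shown here alone, it also remains open whether methoxy on another carbon of the fused system would give a similar step.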